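The source may hold more compounds than are shown below. What is called first, only, known or untested is meant among the compounds shown, and "the series" means these compounds.

In a functional assay on the whole organism for inhibition, with Rattus norvegicus as the target, read by paw edema, with a stated time of 30 min, at a dose of 80 mg/kg by the oral route (a lower number here means a weaker effect, a higher number a stronger effect of the compound at the dose given), compound 1 `COc1ccc(OCC2=NCCO2)cc1` gives 64.1%, compound 2 `Clc1ccc(OCC2=NCCO2)cc1` gives 94.1%, and compound 3 `Brc1ccc(OCC2=NCCO2)cc1` gives 60.1%. The number for compound 3 is the lowest of the three shown, though compound 1 lies within the scatter of it, whereas the step of a number 34 percentage points lower from compound 2 to compound 3 (beyond the scatter) lies beyond it. Compound 4 `O=[N+]([O-])c1ccc(OCC2=NCCO2)cc1` differs from compound 3 by nitro in place of bromo on an aromatic carbon. Going by the values given here, no measured step exchanges a halogen for a nitro group; the nearest guides are a number 4 percentage points lower from compound 1 to compound 3 (within the scatter) and a number 30 percentage points higher from compound 1 to compound 2 (beyond the scatter), which show that an exchange at this carbon can leave the number unchanged or raise it modestly. The expected step is therefore a number 4.9 percentage points higher from compound 3 to compound 4 (within the scatter), small if anything. Compound 4 is accordingly estimated at 65%, within 40% to 90%.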

Compound 4, a percentage reported as inhibition, in the whole organism at one dose (the size of the read-out at that dose, not a potency): 77.1%
Estimate against measurement, compound 4: 12.1 percentage points below; low and high end bracket the measured number.
By their numbers in this assay, from the lowest: compounds 3 and 1 (each within the scatter of the next); then compound 4; then compound 2.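

In this assay the exchange at this aromatic carbon gives an intermediate result: a number 17 percentage points higher from compound 3 to compound 4 (beyond the scatter) and a number 13 percentage points higher from compound 1 to compound 4 (beyond the scatter) both lie beyond the scatter, yet a number 17 percentage points lower from compound 2 to compound 4 (beyond the scatter) keeps nitro short of chloro. A change here can therefore move the number clear of bromo and methoxy without matching chloro, which stays highest of the four groups. As far as these compounds go, whether an amine, a carboxylic acid or fluoro at this carbon would stand nearer chloro or nearer bromo remains open. No measurement shown accounts for this order.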